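The source may hold more compounds than are shown below. What is called first, only, known or untested is meant among the compounds shown, and "the series" means these compounds.

In a functional assay on MDA-MB-231 cells (Homo sapiens), read by microscopy and transwell migration, with a stated time of 24 h (on this read-out lower numbers stand for stronger inhibition and higher numbers for weaker inhibition), compound 1 `COc1cc(-c2csc(NC(=O)c3cccc(OC)c3OC)n2)cc(OC)c1OC` gives 15000 nM, and compound 2 `COc1ccc(C(=O)N(C)c2nc(-c3cc(OC)c(OC)c(OC)c3)cs2)cc1` gives 312 nM. Compound 3 `COc1ccc(C(=O)N(C)c2nc(-c3cc(OC)c(OC)c(OC)c3)cs2)cc1OC` gives > 25000 nM, which is a limit of this assay and not a number. Its true position is therefore unknown, and it offers only a boundary to start from.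

Compound 4 `COc1cc(-c2csc(N(C)C(=O)c3cccc(OC)c3OC)n2)cc(OC)c1OC` has the same atoms as compound 3, joined differently, with 2,3-dimethoxyphenyl in place of 3,4-dimethoxyphenyl on a carbonyl carbon. The methoxy count stays the same and only their arrangement changes.

Among the compounds with values here, one measured step bears on this change: an at least 80-fold higher number from compound 2 to compound 3 (1.90 log units; beyond the scatter). That large step, well beyond the scatter, came from a single methoxy in place of hydrogen on an aromatic carbon, so rearranging the methoxy groups could plausibly matter as well. Compound 1 also carries 2,3-dimethoxyphenyl on its carbonyl carbon and, at 15000 nM, gives a real number rather than a limit.

A move towards a lower number, meaning stronger inhibition, is therefore expected, and the expected size is an at least 6.2-fold lower number from compound 3 to compound 4 (0.79 log units; beyond the scatter). With so few compounds, this expectation remains loose. For compound 4 the estimated value is 4000 nM, with an expected range from 400 nM to 25000 nM.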

Compound 4, half-maximal inhibitory concentration: 108 nM
For compound 4 the middle estimate is 37-fold (1.57 log units) above the measured one; measured number below the stated range.
By their numbers in this assay, from the lowest: compound 4; then compound 2; then compound 1. At a limit, above all of these: compound 3.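

Within this assay, 2,3-dimethoxyphenyl in place of 3,4-dimethoxyphenyl on a carbonyl carbon gives an at least 230-fold lower number from compound 3 to compound 4 (2.36 log units; beyond the scatter), showing that with the same atoms, the arrangement of the methoxy groups alone can separate strong inhibition from none detected at the top of the assay's range. The value for compound 3 is a limit of the assay and not a number, so this step gives only a minimum size: the limit of > 25000 nM in this assay, at which 1 of the 4 values shown sits. The new compound also improves on the 4-methoxyphenyl group, with a 2.9-fold lower number from compound 2 to compound 4 (0.46 log units; beyond the scatter), while methyl in place of hydrogen on the amide-type nitrogen gives a 140-fold lower number from compound 1 to compound 4 (2.14 log units; beyond the scatter), so among these compounds the 2,3-dimethoxyphenyl group gives its lowest number only with that methyl present.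

The compounds shown do not explain why the arrangement of the methoxy groups matters so much, or how much of the effect of the methyl would carry over to other groups on the carbonyl carbon. They also leave open what an ethyl in place of that methyl, or a carboxylic acid on the phenyl ring, would do.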